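Removing the allyl chain: expected effect on minimum effective dose

This account rests on a few compounds, and the source may have more. Where it says the series, first, only, none or still open, it means among the compounds named here.

Three measured compounds share one core. Compound 1 `C=CCc1c(SC)nc2nc(C(=O)c3ccccc3)cn2c1C` in a functional assay on the whole organism with Rattus norvegicus as the target (a higher number here means that more compound is needed for the effect, a lower number that less compound is needed), gives 5 mg/kg. Compound 2 `C=CCc1c(OC)nc2nc(C(=O)c3ccccc3)cn2c1C` gives 5 mg/kg in this assay, and compound 3 `CCCc1c(OC)nc2nc(C(=O)c3ccccc3)cn2c1C` gives 5 mg/kg in this assay. Compound 1 therefore stands level with compounds 2 and 3: the step of no change at the digits printed from compound 1 to compound 2 (within the scatter) and the step of no change at the digits printed from compound 2 to compound 3 (within the scatter) both stayed within the scatter.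

Compound 4 `CSc1cc(C)n2cc(C(=O)c3ccccc3)nc2n1` differs from compound 1 by hydrogen in place of allyl on an aromatic carbon. Neither measured step bears on this directly. One swapped methylsulfanyl for methoxy, the other vinyl for ethyl, and both left the dose unchanged, which suggests that small edits around this part of the core are tolerated in this assay. Removing the whole allyl group is a larger edit than either of those, so the expectation is less certain and a somewhat higher dose seems plausible.

Compound 4 is expected to need about 10 mg/kg in this assay, with a likely range from 3 mg/kg to 30 mg/kg. The step this estimate means is expected to be a 2.0-fold higher number from compound 1 to compound 4 (0.30 log units; within the scatter).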

Compound 4, minimum effective dose: 5 mg/kg
Estimate against measurement, compound 4: 2.0-fold (0.30 log units) above; the range from low to high includes it.
By their numbers in this assay, from the lowest: compounds 1, 2, 3 and 4 (each within the scatter of the next).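

In this assay, hydrogen in place of allyl gives no change at the digits printed from compound 1 to compound 4 (within the scatter), so on this aromatic carbon, ortho to a methyl group and ortho to a methylsulfanyl group, the allyl chain can go entirely without a change beyond the scatter. The earlier steps shown here changed only vinyl to ethyl within the chain, or methylsulfanyl to methoxy, so they could not show whether the compound needs a chain here at all; compound 1 and compound 4 show that, at this read-out, it does not. No supporting data are available to explain why the dose holds.

On these data alone, whether any group on this carbon can shift the dose remains open, since a longer chain, an amine or a carboxylic acid might behave differently from allyl and hydrogen. As far as these compounds go, it is also open whether hydrogen in place of allyl would be equally well tolerated with methoxy in place of methylsulfanyl.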